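A 4-fluorophenyl swap on compound 2

This account rests on a few compounds, and the source may have more. Where it says the series, first, only, none or still open, it means among the compounds named here.

Measured in a toxicity assay on HepG2 2.2.15 cells (Homo sapiens) for cytotoxicity, read by CellTiter-Glo; a higher number here means that more compound is tolerated, a lower number that less compound is tolerated:
Compound 1 `O=C(Nc1cc(F)c(F)c(F)c1)N1Cc2c(-c3ccc(F)cc3F)cnn2CC1C1CC1`: 32100 nM
Compound 2 `O=C1NC(c2ccccc2)CN1c1cnn2c1CN(C(=O)Nc1cc(F)c(F)c(F)c1)C(C1CC1)C2`: 38500 nM
Compound 3 `C[C@H]1Cn2ncc(N3CC(c4ccccc4)CC3=O)c2CN1C(=O)NCc1cc(F)c(F)c(F)c1`: > 2000 nM, a limit and not a number

Among the measured compounds shown here, compound 2 holds one of only two actual numbers in this assay, and the other belongs to compound 1. The two lie within the scatter of each other, as a 1.2-fold higher number from compound 1 to compound 2 (0.08 log units; within the scatter) shows, so neither can be ranked above the other. Compound 3 is known only through its limit of > 2000 nM.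

Compound 4 `O=C(Nc1cc(F)c(F)c(F)c1)N1Cc2c(-c3ccc(F)cc3)cnn2CC1C1CC1` has not yet been measured. It differs from compound 2 as follows: 4-fluorophenyl in place of 2-oxo-4-phenylimidazolidin-1-yl on an aromatic carbon. In words, 4-fluorophenyl stands in place of 2-oxo-4-phenylimidazolidin-1-yl on an aromatic carbon.

For the measured compounds named here, one measured step bears on this change. It put the same 2-oxo-4-phenylimidazolidin-1-yl in place of the 2,4-difluorophenyl of compound 1 on an aromatic carbon, and it gave a 1.2-fold higher number from compound 1 to compound 2 (0.08 log units; within the scatter). The 4-fluorophenyl that enters is close to that 2,4-difluorophenyl, so no change beyond the scatter is expected in this assay. The estimate amounts to a 1.2-fold lower number from compound 2 to compound 4 (0.08 log units; within the scatter), which is expected to be indistinguishable from no change. For compound 4 the estimated value is 32000 nM, with an expected range from 15000 nM to 65000 nM.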

Compound 4, half-maximal cytotoxic concentration: 38500 nM
For compound 4 the middle estimate is 1.2-fold (0.08 log units) below the measured one; the range from low to high includes it.
By their numbers in this assay, from the lowest: compounds 1, 2 and 4 (each within the scatter of the next).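

In this assay, the aromatic carbon of the five-membered aromatic ring with 2 nitrogen has now carried three different groups, 2,4-difluorophenyl, 2-oxo-4-phenylimidazolidin-1-yl and 4-fluorophenyl, and all three compounds lie within the scatter of each other. Exchanging the 2-oxo-4-phenylimidazolidin-1-yl for 4-fluorophenyl gave no change at the digits printed from compound 2 to compound 4 (within the scatter), so a group with a hydrogen-bond donor and acceptor and a ring of carbon only are not told apart at this position. Among the compounds shown here, the change of hydrogen in place of fluoro on an aromatic carbon gave a 1.2-fold higher number from compound 1 to compound 4 (0.08 log units; within the scatter), which shows what the earlier compounds could not: this single fluoro on the phenyl ring leaves the number within the scatter as well.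

On these data alone, it remains open whether a group of another kind on this carbon, such as an amine or a carboxylic acid, would also stay within the scatter in this assay. Compound 3 has only a limit and not a number in this assay, so it cannot be ranked with the other compounds: the limit of > 2000 nM in this assay, at which 1 of the 4 values shown sits.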